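From Methoxy to Dimethylamino on a Fluorinated Core

The source may hold more compounds than are shown below. What is called first, only, known or untested is meant among the compounds shown, and "the series" means these compounds.

- Compound 1 `Nc1ccc(-c2cc(=O)c3c(N)c(F)cc(F)c3o2)cc1F`: 40 nM
- Compound 2 `CCCCCCc1c(F)c(N)c2c(=O)cc(-c3ccc(N)c(F)c3)oc2c1F`: > 10000 nM, a limit and not a number
- Compound 3 `COc1c(F)c(N)c2c(=O)cc(-c3ccc(N)c(F)c3)oc2c1F`: 100 nM

In a functional assay on MCF7 cells (Homo sapiens) for cytotoxicity, read by neutral red uptake, with a stated time of 3 days (on this read-out lower numbers stand for stronger inhibition and higher numbers for weaker inhibition), compound 3 has the higher of the two exact numbers, and compound 1 lies nearest to it. Compound 4 `CN(C)c1c(F)c(N)c2c(=O)cc(-c3ccc(N)c(F)c3)oc2c1F` has dimethylamino in place of methoxy on an aromatic carbon, ortho to two fluoro groups: dimethylamino in place of methoxy on an aromatic carbon. Among the measured compounds shown here, three measured steps bear on this carbon. Methoxy cost little, with a 2.5-fold higher number from compound 1 to compound 3 (0.40 log units; beyond the scatter), whereas hexyl cost far more, with an at least 250-fold higher number from compound 1 to compound 2 (2.39 log units; beyond the scatter). Swapping between those two groups gave an at least 100-fold lower number from compound 2 to compound 3 (2.00 log units; beyond the scatter). Dimethylamino is much closer to methoxy than to hexyl in its counted atoms, so a modest rise is expected, a 2.5-fold higher number from compound 3 to compound 4 (0.40 log units; beyond the scatter). Compound 4 is estimated at 250 nM, with an expected range of 60 nM to 2000 nM.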

Compound 4, half-maximal inhibitory concentration: 39 nM
Estimate against measurement, compound 4: 6.4-fold (0.81 log units) above, outside the stated range (below it).
By their numbers in this assay, from the lowest: compounds 4 and 1 (each within the scatter of the next); then compound 3. At a limit, above all of these: compound 2.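

Replacing methoxy with dimethylamino gives a 2.6-fold lower number from compound 3 to compound 4 (0.41 log units; beyond the scatter), so a group on this carbon need not raise the number, as methoxy and hexyl both did. Against hydrogen the change is a 1.0-fold lower number from compound 1 to compound 4 (0.01 log units; within the scatter), so the two compounds cannot be told apart here. Against hexyl it is an at least 250-fold lower number from compound 2 to compound 4 (2.40 log units; beyond the scatter), a bound only, since compound 2 is held at a limit and not a number: the limit of > 10000 nM in this assay, at which 1 of the 4 values shown sits.

Why dimethylamino and methoxy differ stays open. Diethylamino or a plain amino group on this carbon would show whether the result extends to other amines.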